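The source may hold more compounds than are shown below. What is called first, only, known or untested is meant among the compounds shown, and "the series" means these compounds.

Measured so far in an assay on HEK293 cells for displacement of a labelled ligand from 5-hydroxytryptamine receptor 7 (Rattus norvegicus), read by radioligand binding; on this read-out lower numbers stand for stronger inhibition and higher numbers for weaker inhibition:

compound 1 `CC(C)n1nc2c(c1-c1ccccc1)CCNCC2` gives 28 nM
compound 2 `CC(C)n1nc2c(c1-c1ccc(Cl)cc1)CCNCC2` gives 9 nM
compound 3 `CNc1ccc(-c2c3c(nn2C(C)C)CCNCC3)cc1` gives 40 nM

In this assay compound 2 stands lowest of the three numbers: a 3.1-fold lower number from compound 1 to compound 2 (0.49 log units; beyond the scatter), and a 4.4-fold higher number from compound 2 to compound 3 (0.65 log units; beyond the scatter). Compound 1 and compound 3 sit close together, a 1.4-fold higher number from compound 1 to compound 3 (0.15 log units; within the scatter).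

Compound 4 `CC(C)n1nc2c(c1-c1ccc(Cl)c(Cl)c1)CCNCC2` has not yet been measured. It differs from compound 2 in one place: chloro in place of hydrogen on an aromatic carbon.

Among the compounds with values here, the step that bears most directly on this change is the one from compound 1 to compound 2, where a first chloro replaced hydrogen on the same aromatic ring and gave a 3.1-fold lower number from compound 1 to compound 2 (0.49 log units; beyond the scatter). The steps involving compound 3 show that a methylamino group in that position is not a gain over hydrogen and is a loss against chloro. The present change adds a second chloro rather than a first, and nothing in the series shows how a second such group behaves. A step of the same size as the first is not assumed; a smaller lowering, or none beyond the scatter, is the expectation.

Compound 4 is therefore estimated at 6 nM, with a range of 2 nM to 20 nM. This estimate means a step of a 1.5-fold lower number from compound 2 to compound 4 (0.18 log units; within the scatter).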

Compound 4, inhibition constant: 4000 nM
The estimate for compound 4 lay 670-fold (2.82 log units) below the measured number; the measured number lies above the stated range.
By their numbers in this assay, from the lowest: compound 2; then compounds 1 and 3 (each within the scatter of the next); then compound 4.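

In this assay, the same named change, chloro in place of hydrogen on an aromatic carbon, runs in opposite directions on this ring: one instance lowers the number (a 3.1-fold lower number from compound 1 to compound 2 (0.49 log units; beyond the scatter)), while the instance on the carbon ortho to a chloro group and meta to a large group raises it steeply (a 440-fold higher number from compound 2 to compound 4 (2.65 log units; beyond the scatter)). Within the data shown here, the effect of this change therefore depends on where it is made and on what the ring already carries, so the gain seen with the single chloro group does not carry over to a second one. The entering group is only one heavy atom, with no hydrogen-bond donors or acceptors and no net charge, yet this is the largest step in the series, and no measurement on these compounds accounts for it.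

As far as these compounds go, it remains open whether a chloro group at this place would cost as much in the absence of the existing chloro group, or whether the loss belongs to the pair. Also open, from the compounds shown here alone, is how fluoro, methyl, hydroxyl or an amine would behave on the same carbon.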